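Half-life series: methyl on the phenyl of compound 2

This account rests on a few compounds, and the source may have more. Where it says the series, first, only, none or still open, it means among the compounds named here.

Two compounds of this series have been run in an in vivo ADME assay on the whole organism for metabolic stability, with Rattus norvegicus as the target, using cassette dosing; a higher number here means that the compound lasts longer, a lower number that the compound disappears faster. Compound 1 `CO[C@@H]1C[C@H](C(=O)Nc2ccc(-n3ccccc3=O)cn2)N(C(=O)Nc2ccc(Cl)cc2)C1` gives 2 h in this assay. Compound 2 `O=C(Nc1ccc(-n2ccccc2=O)cn1)[C@H]1C[C@](O)(c2ccccc2)CN1C(=O)Nc1ccc(Cl)cc1` gives 2.9 h in this assay, and its number and that of compound 1 fall within the usual scatter of each other, so no order between the two is read from them. The next compound, compound 3 `Cc1ccc([C@@]2(O)C[C@H](C(=O)Nc3ccc(-n4ccccc4=O)cn3)N(C(=O)Nc3ccc(Cl)cc3)C2)cc1`, has not yet been measured in this assay. Compound 3 differs from compound 2 in one place: methyl in place of hydrogen on an aromatic carbon. Among the measured compounds shown here, no measured pair tracks this kind of change, so there is nothing in hand to set a direction. The step from compound 2 to compound 3 is therefore expected to be small, a 1.2-fold lower number from compound 2 to compound 3 (0.06 log units; within the scatter), and not to go beyond the scatter. For compound 3 the expected half-life in this assay is estimated at 2.5 h, with a range of 1.2 h to 5 h.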

Compound 3, half-life: 1.8 h
Compound 3: middle estimate off by 1.4-fold (0.14 log units), on the high side; the measured number falls inside the stated range.
By their numbers in this assay, from the lowest: compounds 3, 1 and 2 (each within the scatter of the next).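

Among the compounds shown here, the step from phenyl to 4-methylphenyl is the first single-place change measured in this assay, and it gives a 1.6-fold lower number from compound 2 to compound 3 (0.21 log units; within the scatter). A methyl on this aromatic carbon, para to a large group, therefore leaves the half-life of compound 3 within the scatter of that of compound 2, and this single pair sets no direction for the change. Nothing in hand bears on the reason for this result.

Still open, going by these compounds, is whether another group at this same place, such as trifluoromethyl, an amine or a carboxylic acid, would give a step beyond the scatter. Also open, on these data alone, is whether a methyl on another carbon of this phenyl would read the same way.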